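The source may report more compounds than this note shows. Statements on the series, on what has been measured and on what is new or still open speak of the compounds shown alone.

Three members of the series have numbers in a functional assay for inhibition of sodium/hydrogen exchanger (Oryctolagus cuniculus); a higher number here means a weaker inhibitor, a lower number a stronger inhibitor. Compound 1 `Cc1cc(-n2ccnc2C)c(S(C)(=O)=O)cc1C(=O)N=C(N)N` gives 29 nM, compound 2 `Cc1cc(Nc2cccc(Cl)c2)c(S(C)(=O)=O)cc1C(=O)N=C(N)N` gives 33 nM, and compound 3 `Cc1cc(Nc2ncccn2)c(S(C)(=O)=O)cc1C(=O)N=C(N)N` gives 8.3 nM. Compound 3 stands lowest of the three: the steps to it are a 3.5-fold lower number from compound 1 to compound 3 (0.54 log units; beyond the scatter) and a 4.0-fold lower number from compound 2 to compound 3 (0.60 log units; beyond the scatter), both beyond the scatter, whereas a 1.1-fold higher number from compound 1 to compound 2 (0.06 log units; within the scatter) lies within it. Compound 4 `Cc1cc(Oc2cccnc2)c(S(C)(=O)=O)cc1C(=O)N=C(N)N` has not been measured. Its change from compound 3: (pyridin-3-yl)oxy in place of (pyrimidin-2-yl)amino on an aromatic carbon. Among the compounds with values here, the step that bears on this is the one from compound 2 to compound 3, where the (pyrimidin-2-yl)amino group gave the modest drop; compound 4 gives up both the pyrimidin-2-yl ring and the amino link, and nothing in the data shows a pyridin-3-yl ring or an oxy link. The two groups without the pyrimidin-2-yl ring, in compound 1 and compound 2, sit close together. A number near theirs is therefore expected for compound 4, a step back up of about a 3.0-fold higher number from compound 3 to compound 4 (0.48 log units; beyond the scatter). Compound 4 is estimated at 25 nM, with a range from 8 nM to 80 nM.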

Compound 4, half-maximal inhibitory concentration: 8.8 nM
Estimate against measurement, compound 4: 2.8-fold (0.45 log units) above, within the range that was stated.
By their numbers in this assay, from the lowest: compounds 3 and 4 (each within the scatter of the next); then compounds 1 and 2 (each within the scatter of the next).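

In this assay, the (pyridin-3-yl)oxy group of compound 4 and the (pyrimidin-2-yl)amino group read alike at this aromatic carbon ortho to the methylsulfonyl group (a 1.1-fold higher number from compound 3 to compound 4 (0.03 log units; within the scatter)), so a number this low requires neither the pyrimidin-2-yl ring nor the amino link. The two other groups stay apart from compound 4 (a 3.8-fold lower number from compound 2 to compound 4 (0.57 log units; beyond the scatter); a 3.3-fold lower number from compound 1 to compound 4 (0.52 log units; beyond the scatter)), which leaves two different ring-and-link pairs at the low level and the (3-chlorophenyl)amino and 2-methyl-1H-imidazol-1-yl groups at the higher one. No supporting measurement bears on why these two groups read alike.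

Open, from the compounds shown here alone, is how (pyridin-3-yl)amino and (pyrimidin-2-yl)oxy would read, which would separate the ring from the link. Also open, going by these compounds, is how a piperidine ring or a plain amine would compare at this carbon.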